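A few compounds are considered here, and "the series" means these few. Any claim that something is new, unique, unknown or untested is made for them only; others in the source may bear on it.

Of the compounds shown here, two have been tested in a functional assay on the whole organism (Ear) for inhibition, with Mus musculus as the target, with a stated time of 30 min, at a dose of 50 mg/kg by the intraperitoneal route; on this read-out lower numbers stand for less inhibition and higher numbers for more inhibition at the one dose given (going by the name of the read-out). Compound 1, with the structure `N=C(N)N/N=C/c1cn(-c2ccc([N+](=O)[O-])cc2[N+](=O)[O-])nc1-c1ccc(Br)cc1`, gives 69.6%. Compound 2, with the structure `N=C(N)N/N=C/c1cn(-c2ccccc2)nc1-c1ccc(Br)cc1`, gives 42.8%. Compound 2 thus has the lower of the two numbers, and the number for compound 1 lies higher by a margin beyond the usual scatter; the two structures differ in more than one place, so nothing more is drawn from that gap.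

Compound 3, with the structure `N=C(N)N/N=C/c1cn(-c2ccccc2)nc1-c1ccc(F)cc1`, has not yet been tested. It differs from compound 2 in one place: fluoro in place of bromo on an aromatic carbon. Within the data shown here, no measured pair shows what this swap does in this assay, so the expectation rests on compound 2 alone, and a step within the usual scatter, in either direction, is expected from compound 2 to compound 3, put at a number 4.8 percentage points lower from compound 2 to compound 3 (within the scatter). Compound 3 is therefore expected to give about 38%, somewhere between 20% and 58%.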

Compound 3, a percentage reported as inhibition, in the whole organism at one dose (the size of the read-out at that dose, not a potency): 61.4%
For compound 3 the middle estimate is 23.4 percentage points below the measured one; the measured number lies above the stated range.
By their numbers in this assay, from the lowest: compound 2; then compounds 3 and 1 (each within the scatter of the next).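

In this assay, replacing 4-bromophenyl with 4-fluorophenyl gives a number 18.6 percentage points higher from compound 2 to compound 3 (beyond the scatter). Among these compounds, this is the first change in one place alone, and it shows that the read-out responds to which halogen sits on this aromatic carbon, para to a large group. Only one heavy atom is exchanged, while the counts of hydrogen-bond donors, hydrogen-bond acceptors and net charge stay the same, so even a small edit at this position can matter at this dose. Nothing available explains why the step occurs.

The compounds shown leave open how chloro, an amine or a carboxylic acid would read at this position. They also leave open whether the same swap would give a step of similar size on the core of compound 1, with its dinitrophenyl group.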